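The source may hold more compounds than are shown below. What is called first, only, known or untested is meant among the compounds shown, and "the series" means these compounds.

Measured:
compound 1, `COc1cc(OC)c(C(=O)/C=C/c2ccccc2SC)c(OC)c1` — 30%
compound 2, `COc1cc(OC)c(C(=O)/C=C/c2ccc(Cl)cc2)c(OC)c1` — 15%

In a functional assay on PC-3 cells (Homo sapiens), read by fluorescence and BrdU incorporation, with a stated time of 48 h, tested at 10 uM (a lower number here means a stronger effect, a higher number a weaker effect of the compound at the concentration tested), compound 1 gives 30% and compound 2 gives 15%. The step of a number 15 percentage points lower from compound 1 to compound 2 (beyond the scatter) is beyond the scatter, so compound 2 stands lowest of the two numbers, with compound 1 the nearest. Compound 3, `COc1cc(OC)c(C(=O)/C=C/c2ccc(Br)cc2)c(OC)c1`, is not yet measured. It differs from compound 2 by bromo in place of chloro on an aromatic carbon. No measured step exchanges one halogen for another; the only step shown, a number 15 percentage points lower from compound 1 to compound 2 (beyond the scatter), replaces one whole aryl group by another and bears only loosely on this change. An exchange of chloro for bromo on the same aromatic carbon is expected to be a small change, so the expected step is no change at the digits printed from compound 2 to compound 3 (within the scatter), within the scatter. Compound 3 is expected to give about 15%, with a range from 5% to 28%.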

Compound 3, a percentage reported as activity, at one concentration (the size of the read-out at that concentration, not a potency): 35%
Estimate against measurement, compound 3: 20 percentage points below, and the stated range ends below it.
By their numbers in this assay, from the lowest: compound 2; then compounds 1 and 3 (each within the scatter of the next).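

At the aromatic carbon para to a large group, the halogen itself counts in this assay: the exchange gives a number 20 percentage points higher from compound 2 to compound 3 (beyond the scatter) and so moves the read-out toward a weaker effect through one heavy atom alone. The advantage of 4-chlorophenyl over 2-(methylsulfanyl)phenyl (a number 15 percentage points lower from compound 1 to compound 2 (beyond the scatter)) therefore does not carry over to every 4-halophenyl group, since 4-bromophenyl gives a number 5 percentage points higher from compound 1 to compound 3 (within the scatter) against that same group. Nothing available explains why chloro and bromo part here.

As far as these compounds go, with only chloro and bromo at this carbon, it stays open whether fluoro, methoxy or an amine there would read like compound 2 or like compound 3. Also open, from the compounds shown here alone, is whether the chloro and bromo gap persists when the halogen sits elsewhere on the aromatic ring.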